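The compounds below may be only part of what the source reports. "The series", "measured", "known", "first", "only" and "open" are said of these compounds alone.

Working notes on the series. Compound 2 (`COCn1c(CC(O)COCc2ccccc2)c(C)c(=O)[nH]c1=O`) is known only by a limit of the assay: in a functional assay on HeLa cells (Homo sapiens) for antiproliferative activity, read by MTT assay, with a stated time of 72 h (on this read-out lower numbers stand for stronger inhibition and higher numbers for weaker inhibition), compound 2 gives > 100000 nM, which is a limit and not a number. Compound 1 (`Cc1c(CC(O)CO)n(COCC[Si](C)(C)C)c(=O)[nH]c1=O`) is in the same position; in this assay compound 1 gives > 100000 nM, likewise a limit. Among the measured compounds shown here, the picture is summarised by the limit of > 100000 nM in this assay, at which 2 of the 2 values shown sit, so no measured step between two numbered values exists in this set, and nothing can be said about the size of any step between compound 1 and compound 2 beyond that both sit at the limit.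

The next member is compound 3 (`COCn1c(CC(O)CO)c(C)c(=O)[nH]c1=O`). Its change from compound 2 is hydrogen in place of benzyl on an oxygen on a saturated carbon. For the measured compounds named here, with no measured step to anchor the direction, no movement beyond the scatter is expected. Compound 3 is therefore expected to give 150000 nM in this assay, within 50000 nM to 500000 nM, most probably reported as a limit again, which means an expected step that the limit leaves unreadable from compound 2 to compound 3.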

Compound 3, half-maximal inhibitory concentration: > 100000 nM
Compound 3: only a limit was reported; the forecaster's own chance of this, stated with the estimate: 85%; the middle value is on the limit's open side.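

Compound 3 is again known only by a limit, so the steps from compound 1 and from compound 2 to compound 3 cannot be read in this assay: the limit of > 100000 nM in this assay, at which 3 of the 3 values shown sit.

The compounds shown leave open how far past that limit each one lies, and so whether hydrogen in place of benzyl changes anything in this assay.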